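A few compounds are considered here, and "the series" means these few. Any claim that something is new, unique, unknown or untested is made for them only; others in the source may bear on it.

Compound 1 `O=C(Nc1ccc(Oc2ccnc3[nH]ccc23)c(F)c1)c1nn(-c2ccc(Cl)cc2)ccc1=O` and compound 2 `Cn1ccc2c(Oc3ccc(NC(=O)c4nn(-c5ccc(Br)cc5F)ccc4=O)cc3)ccnc21` form the background to this step. In a functional assay on PC-3 cells (Homo sapiens) for cytotoxicity, read by MTT assay, with a stated time of 72 h (on this read-out higher numbers stand for weaker inhibition and lower numbers for stronger inhibition), compound 1 gives 42500 nM. In this assay compound 2 gives 20500 nM. Compound 3 `Cn1ccc2c(Oc3ccc(NC(=O)c4nn(-c5ccc(Cl)cc5)ccc4=O)cc3F)ccnc21` carries a methyl in place of hydrogen on an aromatic nitrogen relative to compound 1, and in this assay compound 3 reaches only the limit of the assay, > 60000 nM. Among the measured compounds shown here, that change gave an at least 1.4-fold higher number from compound 1 to compound 3 (0.14 log units; that floor lies within the scatter), the only single-point step measured here, and it sits at the limit of > 60000 nM in this assay, at which 1 of the 3 values shown sits. Compound 4 `Cn1ccc2c(Oc3ccc(NC(=O)c4nn(-c5ccc(Br)cc5F)ccc4=O)cc3F)ccnc21` differs from compound 3 by 4-bromo-2-fluorophenyl in place of 4-chlorophenyl on an aromatic nitrogen. For the measured compounds named here, no measured step isolates this aryl exchange: compound 1 and compound 2 differ in the aryl group and in the methyl at once, so their two values show only that the bromo-fluoro analogue returns a lower number while also carrying the methyl. From the limit of compound 3 the expected step of an at least 1.2-fold lower number from compound 3 to compound 4 (0.07 log units; that floor lies within the scatter) is therefore small and of uncertain direction. Compound 4 is expected to give about 50000 nM in this assay, between 20000 nM and 120000 nM, with a real chance that only a limit is reported.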

Compound 4, half-maximal inhibitory concentration: 16300 nM
Beside the measured number, compound 4's estimate is 3.1-fold (0.49 log units) above it, and the stated range ends above it.
By their numbers in this assay, from the lowest: compounds 4 and 2 (each within the scatter of the next); then compound 1. At a limit, above all of these: compound 3.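

In this assay, the exchange on the aromatic nitrogen, now seen without any change in the methyl, gave an at least 3.6-fold lower number from compound 3 to compound 4 (0.56 log units; beyond the scatter), so the aryl group at this position shifts the read-out by itself. The fluoro in place of hydrogen on an aromatic carbon gave a 1.3-fold lower number from compound 2 to compound 4 (0.10 log units; within the scatter), so with 4-bromo-2-fluorophenyl in place that fluoro cannot be told apart from hydrogen. The aryl step gives only a floor, not a full size, since the value of compound 3 is a limit: the limit of > 60000 nM in this assay, at which 1 of the 4 values shown sits.

The compounds shown do not separate the bromine from the fluorine within 4-bromo-2-fluorophenyl, so which of the two accounts for the step remains open. Going by these compounds, how an aryl group carrying a methoxy or an amine, or a cyclohexyl group, would read at this position also remains open.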